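A few compounds are considered here, and "the series" means these few. Any claim that something is new, unique, unknown or untested is made for them only; others in the source may bear on it.

Measured so far:
Compound 1 `N[C@H]1CC[C@H](Nc2c(C(=O)NCc3ccco3)nc(Br)c3cccnc23)CC1` – > 10000 nM
Compound 2 `N[C@H]1CC[C@H](Nc2c(C(=O)NCc3ccc(F)cc3)nc(Br)c3cccnc23)CC1` – "not determined" (no result reported)

In a functional assay on HEY cells (Homo sapiens) for cytotoxicity, read by MTT assay, with a stated time of 72 h (on this read-out higher numbers stand for weaker inhibition and lower numbers for stronger inhibition), compound 1 gives > 10000 nM, which is a limit of the assay and not a number. Compound 2 has no number to stand on, as its entry reads "not determined" (no result reported). Within the data shown here, the only reading near it is the limit of > 10000 nM in this assay, at which 1 of the 2 values shown sits.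

Compound 3 `COc1ccc(CNC(=O)c2nc(Br)c3cccnc3c2N[C@H]2CC[C@H](N)CC2)cc1` has not yet been measured in this assay. The structural change is methoxy in place of fluoro on an aromatic carbon, with methoxy in place of fluoro on an aromatic carbon, para to a large group. Among the measured compounds shown here, no measured pair shows what this exchange does, and compound 2 offers no value from which to step. A step no larger than the usual scatter is therefore expected in this assay, with no direction favoured. The expectation leans on compound 1 , whose reading of > 10000 nM is a limit. Weak inhibition is thus expected to persist, and a reading at the limit would be no surprise. Compound 3 is estimated at 8000 nM, with an expected range from 2000 nM to 20000 nM.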

Compound 3, half-maximal inhibitory concentration: 4000 nM
Beside the measured number, compound 3's estimate is 2.0-fold (0.30 log units) above it; low and high end bracket the measured number.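

In this assay, compound 3 holds the only number among the compounds shown, so the group on the amide nitrogen can carry a measurable reading in these cells, and 4-methoxyphenyl in place of furan-2-yl gives an at least 2.5-fold lower number from compound 1 to compound 3 (0.39 log units; beyond the scatter). Compound 1 gives > 10000 nM, which is a limit of the assay and not a number, so the step has a known minimum but no known full size. One end of the step therefore rests on a reading without a true value: the limit of > 10000 nM in this assay, at which 1 of the 3 values shown sits.

As far as these compounds go, compound 2 carries no result, so the step from fluoro to methoxy on the aromatic ring cannot be read, and it stays unknown whether the methoxy group itself matters or whether the benzyl ring alone accounts for the difference from compound 1. A compound with plain hydrogen, a hydroxy group or an ethoxy group in place of the methoxy would separate these readings, while all the compounds shown keep the 4-aminocyclohexyl amine and the bromine of the shared core unchanged, which leaves the contribution of those parts open as well.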